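A few compounds are considered here, and "the series" means these few. Any claim that something is new, unique, unknown or untested is made for them only; others in the source may bear on it.

Working notes on a quinazoline-type series tested in a functional assay on BT-474 cells (Homo sapiens) for antiproliferative activity, read by MTT assay, with a stated time of 72 h; a higher number here means a weaker inhibitor, a lower number a stronger inhibitor. Of the compounds shown here, three have numbers so far. Compound 1 `CC(Nc1nc(N)nc2ccc(-c3cnn(C)c3)cc12)c1c(Cl)ccc(F)c1Cl` gives 7120 nM in this assay. Compound 2 `c1cnc2ccc(Nc3ncnc4ccc(-c5cnn(C6CCNCC6)c5)cc34)cc2c1` gives 12900 nM. Compound 3 `C#Cc1cccc(Nc2ncnc3ccc(-c4cnn(C)c4)cc23)c1` gives 5680 nM, the lowest of the three numbers; against compound 1 the gap lies within the scatter, so no order between those two is claimed, while against compound 2 the gap lies beyond the scatter. The three differ in more than one place from each other, so none of these gaps is tied to a single structural change.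

The next step goes from compound 3 to compound 4 `Cn1cc(-c2ccc3ncnc(Nc4ccc(F)c(Cl)c4)c3c2)cn1`, which is still to be measured in this assay. The change is a single one: 3-chloro-4-fluorophenyl in place of 3-ethynylphenyl on a nitrogen on an aromatic ring. Going by the values given here, nothing among the measured compounds isolates this exchange, so the size of the step cannot be read from the data. The expectation is a step of at most modest size, in either direction, most likely not beyond the scatter. For compound 4 the estimate in this assay is 4500 nM, with a range from 1500 nM to 13000 nM. The step from compound 3 to compound 4 that this estimate means is a 1.3-fold lower number from compound 3 to compound 4 (0.10 log units; within the scatter), and it is expected, not measured.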

Compound 4, half-maximal inhibitory concentration: 5260 nM
Beside the measured number, compound 4's estimate is 1.2-fold (0.07 log units) below it, within the range that was stated.
By their numbers in this assay, from the lowest: compounds 4, 3, 1 and 2 (each within the scatter of the next, the first and the last beyond it).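

Going by these compounds alone, the first exchange that can be read in one place is 3-chloro-4-fluorophenyl in place of 3-ethynylphenyl on a nitrogen on an aromatic ring, and in this assay it gives a 1.1-fold lower number from compound 3 to compound 4 (0.03 log units; within the scatter), a step within the scatter. For this pair, then, the two groups cannot be told apart in this assay, and the triple bond outside aromatic rings can give way to the chlorine and fluorine of the entering group with the rest of the structure held fixed and no step beyond the scatter; this is one pair on one core, not a pattern for the series. Nothing measured alongside these numbers bears on the reason for this outcome.

Still open, as far as these compounds go, is whether any group at this nitrogen moves the number beyond the scatter, for example a phenyl carrying a carboxylic acid or a morpholine in place of the chlorine and fluorine. Also open, from the compounds shown here alone, is whether this exchange gives a comparable step on the cores of compound 1 and compound 2, which differ from compound 3 and compound 4 in more than one place.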